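Swapping Chloro for Bromo on the Anilino Group

The source may hold more compounds than are shown below. What is called first, only, known or untested is meant among the compounds shown, and "the series" means these compounds.

Compound 1 `CCCCNc1nnc(COc2ccc(-c3ccccc3)cc2)s1`: 27.3%
Compound 2 `Clc1ccc(Nc2nnc(COc3ccc(-c4ccccc4)cc3)s2)cc1`: 54.5%

In a functional assay on the whole organism (strain Wistar) for inhibition, with Rattus norvegicus as the target, read by paw edema, with a stated time of 4 h, at a dose of 10 mg/kg by the oral route (a higher number here means more inhibition at the dose given (going by the name of the read-out), a lower number less inhibition), compound 2 gives 54.5%, the higher of the two measured numbers, while compound 1 gives 27.3%. Among the compounds with values here, the only measured step, a number 27.2 percentage points higher from compound 1 to compound 2 (beyond the scatter), placed 4-chlorophenyl where butyl had been. Compound 3 `Brc1ccc(Nc2nnc(COc3ccc(-c4ccccc4)cc3)s2)cc1` carries the change (bromo in place of chloro on an aromatic carbon). Within the data shown here, no measured step exchanges one halogen for another, so the earlier step gives no direct guide here. A change from 4-chlorophenyl to 4-bromophenyl is a small one, and the expected step of a number 0.5 percentage points higher from compound 2 to compound 3 (within the scatter) is thought to stay within the scatter. Compound 3 is therefore estimated at 55%, with a range from 40% to 70%.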

Compound 3, a percentage reported as inhibition, in the whole organism at one dose (the size of the read-out at that dose, not a potency): 63.6%
For compound 3 the middle estimate is 8.6 percentage points below the measured one; the range from low to high includes it.
By their numbers in this assay, from the lowest: compound 1; then compounds 2 and 3 (each within the scatter of the next).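

Bromo in place of chloro on an aromatic carbon gives a number 9.1 percentage points higher from compound 2 to compound 3 (within the scatter) and so, at this place on the ring, the two halogens cannot be told apart. The 4-bromophenyl group in place of butyl gives a number 36.3 percentage points higher from compound 1 to compound 3 (beyond the scatter) and so the gain over butyl seen with 4-chlorophenyl holds with a second halogen. No measurement at hand offers a reason for these numbers. Going by these compounds, whether a halogen is needed here at all remains open, as does what a plain phenyl, a fluoro group or a methoxy group would give at this place.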